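A methoxy swap on a sulfonamide benzoxazole series

The source may hold more compounds than are shown below. What is called first, only, known or untested is meant among the compounds shown, and "the series" means these compounds.

Three compounds share a core in which a sulfonamide links a benzoxazolyl-phenyl piece to a second aromatic ring, and all were tested in an assay on cells for inhibition of HSP60/HSP10 (Homo sapiens), with a stated time of 60 min; on this read-out lower numbers stand for stronger inhibition and higher numbers for weaker inhibition. Compound 1 `O=S(=O)(Nc1ccc(-c2nc3ccccc3o2)cc1)c1ccc(Cl)c(C(F)(F)F)c1` gives 12000 nM in this assay. Compound 3 `O=S(=O)(Nc1ccc(-c2nc3ccccc3o2)cc1)c1ccc(C(F)(F)F)cc1` gives 50000 nM. Compound 2 `Cc1ccc(S(=O)(=O)Nc2ccc(-c3nc4ccccc4o3)cc2)cc1` reaches only the limit of the assay and gives > 100000 nM, a boundary rather than a number; the line the limit of > 100000 nM in this assay, at which 1 of the 3 values shown sits, records this. Among the measured compounds shown here, the one single-point step that is known is an at least 2.0-fold lower number from compound 2 to compound 3 (0.30 log units; that floor lies within the scatter), a floor that sits within the scatter.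

Compound 4 `COc1cccc(S(=O)(=O)Nc2ccc(-c3nc4ccccc4o3)cc2)c1` is the unmeasured member. It differs from compound 2 as 3-methoxyphenyl in place of 4-methylphenyl on a sulfonyl sulfur. For the measured compounds named here, no measured step involves a methoxy group, so the only guide is that compound 2 sits at the limit and the one change made on its ring, in compound 3, moved the number by an amount that could be as small as the scatter. Compound 4 is therefore expected to remain weak, with a number no higher from compound 2 to compound 4 (the limit leaves the size open) as the expected step and a value estimated at 100000 nM, within a range from 30000 nM to 300000 nM.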

Compound 4, half-maximal inhibitory concentration: 80000 nM
Compound 4: the middle estimate sits 1.3-fold (0.10 log units) above what was measured, within the range that was stated.
By their numbers in this assay, from the lowest: compound 1; then compounds 3 and 4 (each within the scatter of the next). At a limit, above all of these: compound 2.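

Among the compounds shown here, putting 3-methoxyphenyl in place of 4-methylphenyl on a sulfonyl sulfur gives a first reading for a methoxy group: in this assay the change is an at least 1.2-fold lower number from compound 2 to compound 4 (0.09 log units; that floor lies within the scatter). The true size of this step cannot be read, because compound 2 has only a limit and not a number: the limit of > 100000 nM in this assay, at which 1 of the 4 values shown sits. The change therefore yields a measured value for compound 4, but it does not establish that 3-methoxyphenyl truly outperforms 4-methylphenyl, even though it adds one hydrogen-bond acceptor.

The compounds shown do not separate the contribution of the oxygen from that of the rest of the methoxy group. From the compounds shown here alone, how an amine or a carboxylic acid would read on this ring also remains open.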